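This account rests on a few compounds, and the source may have more. Where it says the series, first, only, none or still open, it means among the compounds named here.

Working notes on the series in an assay for inhibition of MAP kinase-interacting serine/threonine-protein kinase 1 (Homo sapiens), read by luminescence and ADP-Glo, with a stated time of 2 h; on this read-out lower numbers stand for stronger inhibition and higher numbers for weaker inhibition.

Among the compounds with values here, compound 2 `O=c1ccc(-c2ccc3cn[nH]c3c2)cn1Cc1ccccc1` gives 315 nM in this assay, and this is the only number in the set. Compound 1 `NC(=O)c1ccc(Cn2cc(-c3ccc4cn[nH]c4c3)ccc2=O)cc1` returns only the limit of this assay, > 2000 nM. Compound 3 `Cn1ncc2ccc(-c3ccc(=O)n(Cc4ccccc4)c3)cc21` also returns only the limit, > 2000 nM. Both measured steps are therefore open-ended because of the limit of > 2000 nM in this assay, at which 2 of the 3 values shown sit: an at least 6.3-fold lower number from compound 1 to compound 2 (0.80 log units; beyond the scatter), and an at least 6.3-fold higher number from compound 2 to compound 3 (0.80 log units; beyond the scatter).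

Compound 4 `O=c1ccc(-c2ccc3cn[nH]c3c2)cn1Cc1ccc(Cl)c(Cl)c1` differs from compound 2 by 3,4-dichlorophenyl in place of phenyl on a saturated chain carbon bound to an aromatic nitrogen. Within the data shown here, neither measured step concerns this place: the first alters a group on an aromatic carbon of the distant ring, the second alters the hydrogen on an aromatic nitrogen of the shared core. Among the measured compounds shown here, no step touches the phenyl on the saturated chain carbon bound to an aromatic nitrogen, so nothing in the set argues for a change beyond the scatter in this assay. The expected step is a 1.3-fold lower number from compound 2 to compound 4 (0.10 log units; within the scatter), i.e. none beyond the scatter. Compound 4 is accordingly estimated at 250 nM in this assay, with a range from 70 nM to 900 nM.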

Compound 4, half-maximal inhibitory concentration: 62 nM
The estimate for compound 4 lay 4.0-fold (0.61 log units) above the measured number, and the stated range ends above it.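

In this assay, the phenyl on a saturated chain carbon bound to an aromatic nitrogen proves to be a place where a change can lower the number: 3,4-dichlorophenyl in place of phenyl gives a 5.1-fold lower number from compound 2 to compound 4 (0.71 log units; beyond the scatter). Substitution on this phenyl therefore does not go one way only, since compound 1, with its carbamoyl, and compound 4 lie on opposite sides of compound 2. This is also the first step in the set with a number at both ends, the two earlier steps being open-ended because of this: the limit of > 2000 nM in this assay, at which 2 of the 4 values shown sit.

As far as these compounds go, whether both chlorines are needed, or a single chlorine would give the same step, remains open. So does whether a methoxy, a trifluoromethyl or an amine on this phenyl would follow compound 4 or compound 1.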